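Sulfonyl aryl swap on a benzoxazole sulfonamide, cytotoxicity outlook

The source may report more compounds than this note shows. Statements on the series, on what has been measured and on what is new or still open speak of the compounds shown alone.

Measured compounds:
compound 1, `O=S(=O)(Nc1ccc(-c2nc3ccccc3o2)cc1)c1cccc(F)c1`: > 100000 nM
compound 2, `COc1ccccc1S(=O)(=O)Nc1ccc2oc(-c3ccccc3)nc2c1`: 41000 nM
compound 3, `O=S(=O)(Nc1ccc2oc(-c3ccccc3)nc2c1)c1cccs1`: 97000 nM

Three sulfonamides built on a shared benzoxazole-bearing core have been tested in an ADME assay on HEK293 cells (Homo sapiens) for cytotoxicity, read by resazurin assay, with a stated time of 48 h; on this read-out lower numbers stand for higher toxicity in this test and higher numbers for lower toxicity in this test. Compound 1 gives only a limit of the assay, > 100000 nM, so no number is known for it; it sits at the limit of > 100000 nM in this assay, at which 1 of the 3 values shown sits. Compound 2 gives 41000 nM, and compound 3 gives 97000 nM. Among the measured compounds shown here, their only single-point comparison is a 2.4-fold higher number from compound 2 to compound 3 (0.37 log units; beyond the scatter), in which the aromatic group on the sulfonyl sulfur is exchanged.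

The step now followed leads from compound 1 to compound 4, `COc1ccc(S(=O)(=O)Nc2ccc(-c3nc4ccccc4o3)cc2)cc1`, not yet tested. The change is 4-methoxyphenyl in place of 3-fluorophenyl on a sulfonyl sulfur. For the measured compounds named here, the one measured step that touches the same position, a 2.4-fold higher number from compound 2 to compound 3 (0.37 log units; beyond the scatter), shows a methoxyphenyl on the sulfonyl sulfur giving a lower number than another aromatic group, and only modestly so; it stands on a differently substituted core, so its bearing is loose. Compound 1 offers only a limit, which leaves the starting point open.

Compound 4 is therefore expected to show a modest downward move, an at least 1.2-fold lower number from compound 1 to compound 4 (0.09 log units; that floor lies within the scatter), with the outcome quite possibly again a limit. The estimate for compound 4 is 80000 nM, between 30000 nM and 200000 nM.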

Compound 4, half-maximal cytotoxic concentration: > 100000 nM
Compound 4 was reported as a limit (the forecaster's own chance of this, stated with the estimate: 45%); middle value at least 1.2-fold (0.09 log units) from the limit.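

In this assay, compound 1 and compound 4 are both reported only as a limit, and the step between them cannot be read because both sit at that same limit: the limit of > 100000 nM in this assay, at which 2 of the 4 values shown sit.

The compounds shown leave open what the actual numbers for compound 1 and compound 4 are, and whether 4-methoxyphenyl in place of 3-fluorophenyl changes the read-out at all.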